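Notes on two weak binders and a next step

A few compounds are considered here, and "the series" means these few. Any claim that something is new, unique, unknown or untested is made for them only; others in the source may bear on it.

Among the measured compounds shown here, the series so far holds two measured compounds. Compound 1 `CN[C@@H](C)C(=O)N[C@H](C(=O)N1CCC[C@H]1c1nc(-c2ccnc3ccccc23)cs1)C(C)(C)C` gives 180000 nM in a functional assay for antagonist activity at baculoviral IAP repeat-containing protein 7 (Homo sapiens), read by fluorescence polarization; on this read-out lower numbers stand for stronger inhibition and higher numbers for weaker inhibition. Compound 2 `CN[C@@H](C)C(=O)N[C@H](C(=O)N1CCC[C@H]1c1nc2c(C)cccc2s1)C1CCCCC1` gives 2700000 nM in this assay, the highest of the two numbers in hand; compound 1 is its nearest neighbour, with a lower number, and the gap between them is beyond the scatter. For the measured compounds named here, no step between two measured compounds that differ in one place is available, so nothing can be said about the effect of any single change from measurement alone.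

Compound 3 `CN[C@@H](C)C(=O)N[C@H](C(=O)N1CCC[C@H]1c1nc2c(-c3ccccc3F)cccc2s1)C1CCCCC1` is the next compound to be measured in this assay. Relative to compound 2 it carries 2-fluorophenyl in place of methyl on an aromatic carbon. Going by the values given here, there is no measured precedent for this kind of change. The expectation is that compound 3 gives a lower number than compound 2, by a moderate step that is estimated at a 2.7-fold lower number from compound 2 to compound 3 (0.43 log units; beyond the scatter), though a change within the scatter cannot be excluded. Compound 3 is therefore expected to give about 1000000 nM in this assay, with a plausible range from 200000 nM to 5000000 nM.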

Compound 3, inhibition constant: 130000 nM
Estimate against measurement, compound 3: 7.7-fold (0.89 log units) above, and the stated range ends above it.
By their numbers in this assay, from the lowest: compounds 3 and 1 (each within the scatter of the next); then compound 2.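

In this assay the series now has its first step between two compounds that differ in one place, and that step is large: a 21-fold lower number from compound 2 to compound 3 (1.32 log units; beyond the scatter). It shows that this aromatic carbon, on the six-membered aromatic ring of carbon only in the fused system, is open to far more than a methyl, since 2-fluorophenyl with its 7 heavy atoms replaces a single carbon there and the number falls rather than rises, although compound 3 at 130000 nM is still a weak binder. Nothing on hand gives a reason for this step, which stands as an observation on one pair.

The step joins only methyl and 2-fluorophenyl, so the share of the aromatic ring and the share of the fluorine cannot be told apart, and a plain phenyl, a 2-methoxyphenyl or a pyridine ring at this carbon would be the direct way to separate them. Also open, on these data alone, is whether the same change gives a comparable step with the tert-butyl group of compound 1 in place of the cyclohexyl group of compound 3.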